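Replacing the 4-methoxyphenyl group of compound 1 with 2-chlorophenyl

The source may report more compounds than this note shows. Statements on the series, on what has been measured and on what is new or still open speak of the compounds shown alone.

Compound 1 `COc1ccc(C2C(C#N)=C(N)N(c3cc(OC)c(OC)c(OC)c3)C3=C2C(=O)CC(C)(C)C3)cc1` is the reference for this step. In a functional assay on Ehrlich cells (Mus musculus) for cytotoxicity, tested at 25 ug/mL (on this read-out higher numbers stand for a stronger effect at the one concentration tested and lower numbers for a weaker effect), compound 1 gives 1%, the lowest number of the three measured compounds; the gap to compound 2 is within the scatter, the gap to compound 3 is beyond it. Compound 2 `COc1cc(N2C(N)=C(C#N)C(c3c(O)ccc4ccccc34)C3=C2CC(C)(C)CC3=O)cc(OC)c1OC` gives 10% in this assay, and compound 3 `COc1cc(N2C(N)=C(C#N)C(c3cccc([N+](=O)[O-])c3)C3=C2CC(C)(C)CC3=O)cc(OC)c1OC` gives 20%.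

Compound 4 `COc1cc(N2C(N)=C(C#N)C(c3ccccc3Cl)C3=C2CC(C)(C)CC3=O)cc(OC)c1OC` is not yet measured. It differs from compound 1 in one place: 2-chlorophenyl in place of 4-methoxyphenyl on a saturated ring carbon.

Among the measured compounds shown here, two measured steps bear on this change, since both also exchange the 4-methoxyphenyl group of compound 1 on the same saturated ring carbon. One, a number 9 percentage points higher from compound 1 to compound 2 (within the scatter), stays within the scatter. The other, a number 19 percentage points higher from compound 1 to compound 3 (beyond the scatter), is modest but real. Neither exchange lowers the number, so for compound 4 a small rise is expected, most likely within the scatter and at most modest.

Compound 4 is therefore estimated at 9% in this assay, with a range of 0% to 25%, which corresponds to an expected step of a number 8 percentage points higher from compound 1 to compound 4 (within the scatter).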

Compound 4, a percentage reported as activity, at one concentration (the size of the read-out at that concentration, not a potency): 15%
Beside the measured number, compound 4's estimate is 6 percentage points below it, and the stated range covers the measured number.
By their numbers in this assay, from the lowest: compounds 1, 2, 4 and 3 (each within the scatter of the next, the first and the last beyond it).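

In this assay, a second replacement on this saturated ring carbon now clears the scatter: a number 14 percentage points higher from compound 1 to compound 4 (beyond the scatter), with 2-chlorophenyl entering, so a rise of this kind is not confined to the 3-nitrophenyl group of compound 3, while the step to 2-hydroxynaphthalen-1-yl stays the exception as a number 9 percentage points higher from compound 1 to compound 2 (within the scatter). The three replacements are not separated from one another: a number 5 percentage points lower from compound 3 to compound 4 (within the scatter), and a number 5 percentage points higher from compound 2 to compound 4 (within the scatter). Nothing available gives a cause for the rise over compound 1.

Open, going by these compounds, is how an unsubstituted phenyl group, or a phenyl group bearing a carboxylic acid or an amine, would read on this carbon. Also open is whether these steps hold with a group other than 3,4,5-trimethoxyphenyl on the core, since all the compounds shown carry it.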